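Furanyl Swap at the Edge of the Assay Limit

The source may hold more compounds than are shown below. What is called first, only, known or untested is meant among the compounds shown, and "the series" means these compounds.

Measured compounds in a functional assay on K562 cells (Homo sapiens), read by MTT assay, with a stated time of 72 h; a lower number here means a stronger inhibitor, a higher number a weaker inhibitor:
- Compound 1, `COc1nc(N)nc2c1c(-c1cc3ccccc3o1)cn2[C@@H]1O[C@H](CO)[C@@H](O)[C@H]1O`, gives 14600 nM.
- Compound 2, `COc1nc(N)nc2c1c(-c1ccccc1)cn2[C@@H]1O[C@H](CO)[C@@H](O)[C@H]1O`, gives only a limit of the assay, > 20000 nM.
- Compound 3, `COc1nc(N)nc2c1c(-c1ccoc1)cn2[C@@H]1O[C@H](CO)[C@@H](O)[C@H]1O`, likewise gives only a limit of the assay, > 20000 nM.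

Compound 3 thus stands at the limit rather than at a number, as does compound 2 (the limit of > 20000 nM in this assay, at which 2 of the 3 values shown sit). The step to compound 4, `COc1nc(N)nc2c1c(-c1ccco1)cn2[C@@H]1O[C@H](CO)[C@@H](O)[C@H]1O`, changes the group on the core: furan-2-yl in place of furan-3-yl on an aromatic carbon.

Two measured steps reach compound 3. From compound 1 the change is an at least 1.3-fold higher number from compound 1 to compound 3 (0.13 log units; that floor lies within the scatter); from compound 2 it is a step that the two limits leave unreadable from compound 2 to compound 3. For the measured compounds named here, neither step fixes a number for compound 3, so the change to furan-2-yl has no directly comparable measured precedent; the only group attached through its 2-position in the set, 1-benzofuran-2-yl in compound 1, sits at a measured value near the limit.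

Compound 4 is therefore expected to stay near the limit, with a step of a number no higher from compound 3 to compound 4 (the limit leaves the size open). The estimate for compound 4 is 20000 nM, between 8000 nM and 50000 nM.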

Compound 4, half-maximal inhibitory concentration: > 20000 nM
Compound 4 was reported as a limit (the forecaster's own chance of this, stated with the estimate: 60%); the middle value lies on the limit itself.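

In this assay, furan-2-yl in place of furan-3-yl leaves this position without a measured number, and the limit now spans most of the set: the limit of > 20000 nM in this assay, at which 3 of the 4 values shown sit. Phenyl, furan-3-yl and furan-2-yl therefore cannot be ranked, as the steps among compound 2, compound 3 and compound 4 cannot be read. Compound 1 alone gives a number, yet the comparison with 1-benzofuran-2-yl shows an at least 1.3-fold higher number from compound 1 to compound 4 (0.13 log units; that floor lies within the scatter), so even this contrast is not shown to exceed the usual scatter.

As far as these compounds go, it remains open whether the three groups at the limit truly differ in this assay, since their values give no sizes. From the compounds shown here alone, it also remains open whether another fused group, such as 1-benzothiophen-2-yl or naphthalen-2-yl, would give a value clearly separated from the limit.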